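The source may hold more compounds than are shown below. What is called first, only, known or untested is meant among the compounds shown, and "the series" means these compounds.

Of the compounds shown here, three built on one shared core have been tested in a functional assay for inhibition, with Homo sapiens as the target; on this read-out higher numbers stand for weaker inhibition and lower numbers for stronger inhibition. Compound 1 `CCCc1ncc2cnnc(S)n12` carries a propyl group on the core. In this assay compound 1 gives no number, only a limit of the assay, > 48000 nM. Compound 2 `CCCc1ncc2c(C)nnc(S)n12` has a methyl in place of hydrogen on an aromatic carbon of compound 1. In this assay compound 2 likewise stops at a limit, > 48000 nM. Compound 3 `Cc1nnc(S)n2cncc12` keeps that methyl but has hydrogen in place of propyl on an aromatic carbon. In this assay compound 3 also reaches only a limit, > 48000 nM. Among the compounds with values here, the two measured steps, a step that the two limits leave unreadable from compound 1 to compound 2 and a step that the two limits leave unreadable from compound 2 to compound 3, therefore cannot be sized: every value so far is the limit of > 48000 nM in this assay, at which 3 of the 3 values shown sit. Compound 2 thus stands at a limit rather than at a number, and nothing separates it from the other two.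

Compound 4 `CCCc1ncc2c(C)nnc(O)n12` differs from compound 2 in one place: hydroxy in place of sulfanyl on an aromatic carbon. Within the data shown here, no measured step touches this kind of change, and the two that exist are unreadable, so there is no basis for expecting any shift beyond the scatter in this assay. The expectation is that the step from compound 2 to compound 4 will be a step that the limit leaves unreadable from compound 2 to compound 4. Compound 4 is accordingly expected to give about 100000 nM, within a range from 30000 nM to 500000 nM, and most likely to remain at a limit.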

Compound 4, half-maximal inhibitory concentration: > 48000 nM
Compound 4: a limit, no number; the forecaster's own chance of this, stated with the estimate: 85%; the middle value is on the limit's open side.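

In this assay compound 4 gives only a limit of the assay, > 48000 nM. The change from compound 2 to compound 4, hydroxy in place of sulfanyl, therefore cannot be sized, and all four compounds stand alike: the limit of > 48000 nM in this assay, at which 4 of the 4 values shown sit. The compounds shown leave open how strongly any of them inhibits, and whether any of these changes to the shared core alters inhibition at all.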